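This account rests on a few compounds, and the source may have more. Where it says the series, first, only, none or still open, it means among the compounds named here.

In a functional assay on A549 cells (Homo sapiens) for antiproliferative activity, read by sulforhodamine B assay, with a stated time of 48 h (a lower number here means a stronger inhibitor, a higher number a weaker inhibitor), compound 3 `COc1cccc(/C=C/C(=O)C(=Cc2ccc(O)c(F)c2)C(=O)/C=C/c2cccc(OC)c2OC)c1OC` gives 200 nM, within the scatter of compound 1 `COc1cccc(/C=C/C(=O)C(=Cc2cc(OC)c(OC)c(OC)c2)C(=O)/C=C/c2cccc(OC)c2OC)c1OC` at 230 nM, while compound 2 `COc1cc(OC)c(C=C(C(=O)/C=C/c2cccc(OC)c2OC)C(=O)/C=C/c2cccc(OC)c2OC)c(OC)c1` gives 630 nM. Compound 4 `COc1cc(C=C(C(=O)/C=C/c2cccc(OC)c2OC)C(=O)/C=C/c2cccc(OC)c2OC)cc(Br)c1O` keeps the shared core and carries 3-bromo-4-hydroxy-5-methoxyphenyl in place of 3-fluoro-4-hydroxyphenyl on a double-bonded chain carbon bound to a double-bonded chain carbon. Three measured steps replaced a group at this same place: a 1.2-fold lower number from compound 1 to compound 3 (0.06 log units; within the scatter), a 2.7-fold higher number from compound 1 to compound 2 (0.44 log units; beyond the scatter) and a 3.2-fold lower number from compound 2 to compound 3 (0.50 log units; beyond the scatter). None of these steps was more than modest, and only compound 2 stands apart, so no step beyond the scatter is expected in this assay. The expected change is a 1.3-fold higher number from compound 3 to compound 4 (0.10 log units; within the scatter). Compound 4 is estimated at 250 nM, with an expected range of 100 nM to 620 nM.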

Compound 4, half-maximal inhibitory concentration: 200 nM
Compound 4: the middle estimate sits 1.3-fold (0.10 log units) above what was measured; measured number inside the range.
By their numbers in this assay, from the lowest: compounds 3, 4 and 1 (each within the scatter of the next); then compound 2.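

In this assay the change to 3-bromo-4-hydroxy-5-methoxyphenyl leaves the number where it was, with no change at the digits printed from compound 3 to compound 4 (within the scatter) and a 1.2-fold lower number from compound 1 to compound 4 (0.06 log units; within the scatter), so this place accepts a larger, bromine-bearing ring without a step beyond the scatter. Compound 2 remains the only one apart, with a 3.2-fold lower number from compound 2 to compound 4 (0.50 log units; beyond the scatter), which is the same gap that separates it from compound 3. No measurement shown here accounts for this result. From the compounds shown here alone, whether an amine or a carboxylic acid on the phenyl ring at this place would hold the number remains open.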